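Replacing naphthalen-1-yl with 4-(dimethylamino)phenyl

The compounds below may be only part of what the source reports. "The series", "measured", "known", "first", "only" and "open" are said of these compounds alone.

In a functional assay on A2780 cells (Homo sapiens) for cytotoxicity, read by MTT assay, with a stated time of 72 h (a lower number here means a stronger inhibitor, a higher number a weaker inhibitor), compound 1 `O=C(CCCCCN(CC(=O)NC1CCCCC1)C(=O)c1ccccc1)NO` gives 3460 nM, while compound 2 `O=C(CCCCCN(CC(=O)NC1CCCCC1)C(=O)c1cccc2ccccc12)NO` gives 260 nM, the lower of the two numbers. Within the data shown here, the only measured step, a 13-fold lower number from compound 1 to compound 2 (1.12 log units; beyond the scatter), is large and beyond the scatter, and it came from replacing phenyl with naphthalen-1-yl on a carbonyl carbon. Compound 3 `CN(C)c1ccc(C(=O)N(CCCCCC(=O)NO)CC(=O)NC2CCCCC2)cc1` differs from compound 2 in that same place: 4-(dimethylamino)phenyl in place of naphthalen-1-yl on a carbonyl carbon. It has 4-(dimethylamino)phenyl in place of naphthalen-1-yl, so it returns to one aromatic ring, as in compound 1, but with a dimethylamino group added. No measurement shows what that added group does. The step in compound 1 to compound 2 suggests that losing naphthalen-1-yl should raise the number, though probably by less than that full step. The expected change is a 3.8-fold higher number from compound 2 to compound 3 (0.59 log units; beyond the scatter). For compound 3, the estimated value is 1000 nM, with a range from 300 nM to 3500 nM.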

Compound 3, half-maximal inhibitory concentration: 1540 nM
Compound 3: middle estimate off by 1.5-fold (0.19 log units), on the low side; the measured number falls inside the stated range.
By their numbers in this assay, from the lowest: compound 2; then compound 3; then compound 1.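

In this assay, dimethylamino in place of hydrogen on an aromatic carbon brings a 2.2-fold lower number from compound 1 to compound 3 (0.35 log units; beyond the scatter), so a group added to the single ring on this carbonyl carbon can lower the number, which compound 1 and compound 2 alone could not show. That added group does not make up for the second aromatic ring, as 4-(dimethylamino)phenyl in place of naphthalen-1-yl brings a 5.9-fold higher number from compound 2 to compound 3 (0.77 log units; beyond the scatter). Nothing available explains either step.

From the compounds shown here alone, it remains open whether another group in place of that hydrogen, such as methoxy or a chlorine atom, would lower the number as dimethylamino does. Also unsettled is whether naphthalen-2-yl on this carbonyl carbon would match naphthalen-1-yl, or whether a dimethylamino group on naphthalen-1-yl would lower the number further.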